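Cyclohexyl in place of 1-phenylethyl: expected inhibition

The source may report more compounds than this note shows. Statements on the series, on what has been measured and on what is new or still open speak of the compounds shown alone.

Measured so far:
compound 1, `COc1cc(O)c(C(=O)OCC(C)c2ccccc2)c(/C=C/CN2C(=O)C=CC2=O)c1`: 0%
compound 2, `CCN(CC)C/C=C/C(=O)NC/C=C/c1cc(OCCc2ccc(F)cc2)cc(O)c1C(=O)OC(C)C`: 0.8%

In an assay on isolated protein for inhibition of MAP kinase-interacting serine/threonine-protein kinase 2 (Homo sapiens), tested at 10 uM (a higher number here means more inhibition at the concentration tested (going by the name of the read-out), a lower number less inhibition), compound 1 gives 0%. Compound 2 gives 0.8%, and the two numbers lie within the scatter of each other, so neither stands apart from the other. Both compounds show essentially no inhibition at the concentration tested.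

Compound 3, `COc1cc(O)c(C(=O)OCC2CCCCC2)c(/C=C/CN2C(=O)C=CC2=O)c1`, is not yet measured. It differs from compound 1 in one place: cyclohexyl in place of 1-phenylethyl on a saturated chain carbon bound to an oxygen next to a carbonyl group. Among the compounds with values here, no step between measured compounds has been recorded, so the data give no direct reading of what this change does. Both measured compounds sit at the floor of the read-out and the rest of the structure is unchanged. For compound 3 the step of a number 2 percentage points higher from compound 1 to compound 3 (within the scatter) is expected to stay within the scatter, with no direction implied. Compound 3 is therefore estimated at 2%, in a range from -8% to 12%.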

Compound 3, a percentage reported as inhibition, at one concentration (the size of the read-out at that concentration, not a potency): 0%
Compound 3: middle estimate off by 2 percentage points, on the high side; the range from low to high includes it.
By their numbers in this assay, from the lowest: compounds 1, 3 and 2 (each within the scatter of the next).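

In this assay cyclohexyl in place of 1-phenylethyl on a saturated chain carbon bound to an oxygen next to a carbonyl group gives no change at the digits printed from compound 1 to compound 3 (within the scatter) with the rest of compound 1 unchanged. Within the data shown here, this is the first reading at this position: with the core of compound 1 held fixed, neither the aromatic ring of 1-phenylethyl nor the non-aromatic ring of cyclohexyl lifts the value off the bottom of the read-out. With both values at that bottom, the step cannot show whether this position matters in a compound that does inhibit. No measured information bears on this result. Still open, as far as these compounds go, is whether an amine or a carboxylic acid on this ester chain would give measurable inhibition. Also open, from the compounds shown here alone, is whether any such reading would hold on a different core.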